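Replacing allyl with 2,6-dimethylphenyl: notes on compound 4

A few compounds are considered here, and "the series" means these few. Any claim that something is new, unique, unknown or untested is made for them only; others in the source may bear on it.

Measured so far in a functional assay on MCF7 cells (Homo sapiens) for antiproliferative activity, read by MTT assay, with a stated time of 72 h; a lower number here means a stronger inhibitor, a higher number a weaker inhibitor (one line per compound)
- Compound 1 `C=CC/N=C1\S/C(=C\c2ccc(OC)cc2)C(=O)N1C` gives > 100000 nM (a limit)
- Compound 2 `COc1ccc(/C=C2/CN(C)/C(=N/c3ccc(C(C)(C)C)cc3)S2)cc1` gives 28700 nM (a number)
- Compound 3 `COc1ccc(/C=C2/CN(C)/C(=N/c3ccc(C(F)(F)F)cc3)S2)cc1` gives 24100 nM (a number)

Compound 1 sits at the limit of > 100000 nM in this assay, at which 1 of the 3 values shown sits, and has no number of its own. Compound 4 `COc1ccc(/C=C2\S/C(=N\c3c(C)cccc3C)N(C)C2=O)cc1` is the next to be read. The change from compound 1 is 2,6-dimethylphenyl in place of allyl on a double-bonded nitrogen. Within the data shown here, the only measured step, a 1.2-fold lower number from compound 2 to compound 3 (0.08 log units; within the scatter), is trifluoromethyl in place of tert-butyl on an aromatic carbon, so it leaves the group on that nitrogen untouched and bears only loosely on this change. It does suggest that the choice of group on that aromatic ring need not move the reading much. Compound 2 at 28700 nM and compound 3 at 24100 nM both carry an aromatic ring on a double-bonded nitrogen and both give numbers, which is the main ground for expecting compound 4 to read lower than compound 1. Among the measured compounds shown here, their core is not that of compound 1, and no measured step joins them to it, so compound 4 may still return only a limit. The expected step is an at least 2.8-fold lower number from compound 1 to compound 4 (0.45 log units; beyond the scatter) (an estimate, towards a lower number). Expected for compound 4 is 35000 nM (estimated range 10000 nM to 100000 nM).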

Compound 4, half-maximal inhibitory concentration: > 100000 nM
Compound 4: only a limit was reported; the forecaster's own chance of this, stated with the estimate: 35%; middle value at least 2.8-fold (0.45 log units) from the limit.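

No step can be read from compound 1 to compound 4, since each gives only a limit and not a number: the limit of > 100000 nM in this assay, at which 2 of the 4 values shown sit.

The compounds shown leave open whether 2,6-dimethylphenyl in place of allyl on a double-bonded nitrogen changes the reading at all on the core of compound 1.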